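The compounds below may be only part of what the source reports. "The series", "measured", "known", "first", "only" and "open" are said of these compounds alone.

Measured compounds:
- compound 1, `NC(=O)[C@@H]1CCCN1c1cc(=O)oc2cc(OCc3ccccc3)ccc12`: in an assay (strain Wistar) for inhibition of Amine oxidase [flavin-containing] A (Rattus norvegicus) (a higher number here means a weaker inhibitor, a lower number a stronger inhibitor), compound 1 gives 99800 nM
- compound 2, `NNC(=O)Cc1cc(=O)oc2cc(OCc3cccc(Cl)c3)ccc12`: in this assay compound 2 gives 2500 nM

Compound 1 stands at the higher of the two numbers, so it is the weaker inhibitor of the pair; compound 2 sits at a number far enough below it to lie beyond the usual scatter. The two compounds differ in more than one place, so their gap cannot be assigned to any single change.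

Compound 3, `NCc1cc(=O)oc2cc(OCc3ccccc3)ccc12`, has not been measured yet. It differs from compound 1 in one place: aminomethyl in place of 2-carbamoylpyrrolidin-1-yl on an aromatic carbon. The group that leaves is large and carries a ring and an amide; the group that enters is small. Going by the values given here, no pair of measured compounds shows this exact change, so the size of the step is open. Still, a move towards a lower number is expected rather than none, and the step from compound 1 to compound 3 is estimated at a 12-fold lower number from compound 1 to compound 3 (1.10 log units; beyond the scatter). For compound 3 the expected value in this assay is 8000 nM, with a range from 800 nM to 80000 nM.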

Compound 3, half-maximal inhibitory concentration: 4400 nM
Beside the measured number, compound 3's estimate is 1.8-fold (0.26 log units) above it; the range from low to high includes it.
By their numbers in this assay, from the lowest: compounds 2 and 3 (each within the scatter of the next); then compound 1.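

In this assay, going by these compounds alone, the change at the aromatic carbon opposite the ring oxygen, from 2-carbamoylpyrrolidin-1-yl to aminomethyl, gives a 23-fold lower number from compound 1 to compound 3 (1.36 log units; beyond the scatter) and is the first single-place step seen here. Compound 3 is the stronger inhibitor of this pair even though it carries the much smaller group, so the ring and amide of the larger group are not required for inhibition at this level. No measurement is available to explain why the number falls.

The ring, the amide and the defined stereocentre all leave in this one step, so the compounds shown cannot say which of them accounts for the change. They also leave open how a plain pyrrolidin-1-yl, a longer chain such as 2-aminoethyl, or a simple methyl with no nitrogen would behave at this position.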